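Swapping a Phenethyl Chain for Thiophene on the Shared Core

The compounds below may be only part of what the source reports. "The series", "measured", "known", "first", "only" and "open" are said of these compounds alone.

Two compounds built on closely related cores carry the same bromoacrylamide-bearing aryl arm and have been tested in a functional assay on L1210 cells (Mus musculus) for inhibition, read by cell counting, with a stated time of 2 days; on this read-out higher numbers stand for weaker inhibition and lower numbers for stronger inhibition. Compound 1, `C=C(Br)C(=O)Nc1cccc(-c2cn3c(-c4ccc(OC)cc4)csc3n2)c1`, gives 200 nM in this assay. Compound 2, `C=C(Br)C(=O)Nc1cccc(-c2cn3nc(CCc4ccccc4)sc3n2)c1`, gives 2200 nM in this assay, which is the higher of the two numbers, and its gap from compound 1 lies beyond the usual scatter, so compound 2 is the weaker of the pair as measured.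

Among the measured compounds shown here, the next compound, compound 3, `C=C(Br)C(=O)Nc1cccc(-c2cn3nc(-c4cccs4)sc3n2)c1`, keeps the core of compound 2 and changes only one group: thiophen-2-yl in place of phenethyl on an aromatic carbon. Since compound 1 and compound 2 differ in more than one place, their two values alone cannot show what this single swap will do. Against that background only a cautious expectation is possible. In this assay the change from compound 2 to compound 3 is expected to give a moderate improvement, a 2.8-fold lower number from compound 2 to compound 3 (0.44 log units; beyond the scatter), not far beyond the scatter. Compound 3 is therefore estimated at 800 nM, with a range from 200 nM to 3000 nM.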

Compound 3, half-maximal inhibitory concentration: 170 nM
Beside the measured number, compound 3's estimate is 4.7-fold (0.67 log units) above it; measured number outside the range, below it.
By their numbers in this assay, from the lowest: compounds 3 and 1 (each within the scatter of the next); then compound 2.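

In this assay, placing thiophen-2-yl in place of phenethyl gives a 13-fold lower number from compound 2 to compound 3 (1.11 log units; beyond the scatter), a large step for a change at one site. Among the compounds shown here, compound 1 and compound 2 differ in more than one place, so their gap could not be tied to any single group, whereas here only this group changes, on an aromatic carbon of the five-membered aromatic ring with 2 nitrogen and 1 sulfur. This pair therefore shows that the group at this position can, on its own, move the read-out by far more than the usual scatter, but no measurement shown here explains why the number falls so far.

The compounds shown leave open whether this result belongs to thiophen-2-yl in particular or to any aromatic ring attached directly at this position, a question that a phenyl or a furan-2-yl group there would help to settle. They also leave open whether a shorter chain such as benzyl would behave like phenethyl, and whether thiophen-2-yl would have an effect of similar size on the core of compound 1.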